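Ester to Dimethylamide on a Shared Core

The source may report more compounds than this note shows. Statements on the series, on what has been measured and on what is new or still open speak of the compounds shown alone.

Compound 1 `CCOC(=O)c1cc(CCCOc2ccc(-c3noc(C(F)(F)F)n3)cc2[N+](=O)[O-])on1` was tested in an ADME assay on HeLa cells (Homo sapiens) for cytotoxicity, read by crystal violet staining, with a stated time of 72 h; a higher number here means that more compound is tolerated, a lower number that less compound is tolerated. In this assay compound 1 gave only a limit, > 100000 nM, not a number. Compound 2 `CCOC(=O)c1cc(CCCOc2c(OC)cc(-c3noc(C(F)(F)F)n3)cc2[N+](=O)[O-])on1` carries a methoxy in place of hydrogen on an aromatic carbon; in this assay compound 2 likewise gave only a limit, > 100000 nM. The step that the two limits leave unreadable from compound 1 to compound 2 cannot be sized, since (the limit of > 100000 nM in this assay, at which 2 of the 2 values shown sit). Compound 3 `COc1cc(-c2noc(C(F)(F)F)n2)cc([N+](=O)[O-])c1OCCCc1cc(C(=O)N(C)C)no1` differs from compound 2 in one place: dimethylamino in place of ethoxy on a carbonyl carbon. Among the compounds with values here, no measured step covers this change, and the only step on record is itself unreadable, so the expectation rests on the two limits alone. The tolerated concentration of compound 3 in this assay is expected to stay at the same limit, a step that the limit leaves unreadable from compound 2 to compound 3 that is expected to be no larger than the scatter. Compound 3 is therefore estimated at 150000 nM, within 50000 nM to 500000 nM.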

Compound 3, half-maximal cytotoxic concentration: 25600 nM
Compound 3: middle estimate off by 5.9-fold (0.77 log units), on the high side; the whole stated range lies above it.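

Placing dimethylamino instead of ethoxy on the carbonyl carbon gives an at least 3.9-fold lower number from compound 2 to compound 3 (0.59 log units; beyond the scatter) in this assay, so this position can change how much compound the cells tolerate. Within the data shown here, compound 3 gives 25600 nM, the first real number, which shows that cytotoxicity can be measured on this shared core within the range of the assay. The earlier step, the methoxy change from compound 1 to compound 2, cannot be read, as neither compound has a number to compare: the limit of > 100000 nM in this assay, at which 2 of the 3 values shown sit.

Going by these compounds, the true size of the new step remains open, since only its smallest possible size is known. Also open, on these data alone, is whether a carboxylic acid or a methylamino group on the same carbonyl carbon would lower the number too, and whether dimethylamino would do the same on the core of compound 1.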